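Trimming the Cyclohexyl Group of Compound 1

A few compounds are considered here, and "the series" means these few. Any claim that something is new, unique, unknown or untested is made for them only; others in the source may bear on it.

Within the data shown here, in a functional assay on SK-BR-3 cells (Homo sapiens) for cytotoxicity, read by MTT assay, with a stated time of 72 h (on this read-out lower numbers stand for an effect already at smaller amounts and higher numbers for an effect only at larger amounts of compound), compound 1 `COc1ccc(Nc2cc(C3CCCCC3)oc(=O)c2)cc1` gives 5.29 uM, the highest of the three numbers measured so far. Compound 2 `Cc1ccc(Nc2cc(-c3ccccc3)oc(=O)c2)cc1` gives 0.09 uM and compound 3 `COc1ccc(Nc2cc(-c3ccc4ccccc4c3)oc(=O)c2)cc1` gives 0.13 uM. Both numbers lie far lower, beyond the usual scatter, but neither compound has a cyclohexyl group, and compound 2 differs from compound 1 in more than one place.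

The next structure, compound 4 `COc1ccc(Nc2cc(C(C)C)oc(=O)c2)cc1`, keeps the rest of compound 1 and carries isopropyl in place of cyclohexyl on an aromatic carbon. Among the measured compounds shown here, no measured pair shows a change at this place alone, so any forecast is uncertain. For the measured compounds named here, the best anchor is compound 1 at 5.29 uM, the only measured compound with a cyclohexyl group. A small move towards a higher number is expected, possibly none beyond the scatter, and the estimated step is a 1.5-fold higher number from compound 1 to compound 4 (0.18 log units; within the scatter). For compound 4, the estimated value in this assay is 8 uM, with an expected range from 2.5 uM to 30 uM.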

Compound 4, concentration for half-maximal effect: > 30 uM
Compound 4: a limit, no number; the forecaster's own chance of this, stated with the estimate: 15%; at least 3.7-fold (0.57 log units) between middle value and limit.
By their numbers in this assay, from the lowest: compounds 2 and 3 (each within the scatter of the next); then compound 1. At a limit, above all of these: compound 4.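

The change from cyclohexyl to isopropyl, at the place next to the ring oxygen, gives an at least 5.6-fold higher number from compound 1 to compound 4 (0.75 log units; beyond the scatter). Among these compounds, this is the first step read at this position, and it shows that the position is not indifferent in this assay: with the rest of the structure kept, the smaller, ring-free isopropyl does not hold the cytotoxic effect that compound 1 shows. Compound 4 gives only a limit, not a number, so the step has a floor but no known size: the limit of > 30 uM in this assay, at which 1 of the 4 values shown sits.

Going by these compounds, what remains open is how the number moves with other groups at this place on the core of compound 1. A cyclopentyl ring, a longer chain such as n-hexyl, or an amine such as morpholine could each show whether the ring or the number of carbons matters more.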